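The source may hold more compounds than are shown below. What is called first, only, known or untested is meant among the compounds shown, and "the series" means these compounds.

Series notes on the shared core and its ring-bound oxygen substituent.

Compound 1 `CO[C@H]1CC[C@H]2CCN(C)[C@H]2C1` is measured in an assay on HEK293 cells for displacement of a labelled ligand from Neuronal acetylcholine receptor; alpha4/beta4 (Rattus norvegicus), with a stated time of 4 h; on this read-out lower numbers stand for stronger inhibition and higher numbers for weaker inhibition; for compound 1 the read-out is a limit of the assay, > 300000 nM, and not a number. Compound 2 `CCO[C@H]1CC[C@H]2CCN(C)[C@H]2C1` likewise gives only a limit in this assay, > 300000 nM. Compound 3 `COCCO[C@H]1CC[C@H]2CCN(C)[C@H]2C1` stands on the same footing: in this assay compound 3 returns a limit, > 300000 nM, rather than a measured number. All three values sit at the limit of > 300000 nM in this assay, at which 3 of the 3 values shown sit, so the steps a step that the two limits leave unreadable from compound 1 to compound 2, a step that the two limits leave unreadable from compound 1 to compound 3 and a step that the two limits leave unreadable from compound 2 to compound 3 cannot be read in size or in direction.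

Compound 4 `CN1CC[C@@H]2CC[C@H](O)C[C@@H]21` differs from compound 3 by hydrogen in place of 2-methoxyethyl on an oxygen on a saturated carbon; cut one bond further out the change reads 2-methoxyethoxy to hydroxy. For the measured compounds named here, no measured step bears directly on removing the whole ether chain, and the three unreadable steps offer no direction to build on. With every measured compound at the limit, compound 4 is expected to stay near that limit as well, and the step that the limit leaves unreadable from compound 3 to compound 4 is an estimate without a measured counterpart. The estimate for compound 4 in this assay is 500000 nM, within the range 100000 nM to 3000000 nM, with a reported limit rather than a number being the likelier outcome.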

Compound 4, inhibition constant: > 300000 nM
Compound 4 ended at the assay's limit (the forecaster's own chance of this, stated with the estimate: 85%); the middle value lies beyond the limit too.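

In this assay compound 4 gives > 300000 nM, a limit and not a number. The steps from compound 1, compound 2 and compound 3 to compound 4 cannot be read in size or direction: the limit of > 300000 nM in this assay, at which 4 of the 4 values shown sit.

The compounds shown leave open whether any change to the shared core or its oxygen substituent gives a measurable value in this assay.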